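Lengthening the chain on the ring amine

The source may hold more compounds than are shown below. What is called first, only, known or untested is meant among the compounds shown, and "the series" means these compounds.

Compound 2 `CCN1CCC(NC(=O)c2cc(Cl)c(N)cc2OC)CC1` gives the higher of the two numbers measured in an assay on HEK293 cells for displacement of a labelled ligand from 5-hydroxytryptamine receptor 4 (Homo sapiens), read by scintillation counting; a lower number here means a stronger inhibitor, a higher number a weaker inhibitor. Compound 2 gives 1000 nM there, while compound 1 `CC(C)n1c(=O)n(C(=O)NCCN2CCNCC2)c2ccccc21` gives 126 nM, a gap beyond the usual scatter. Compound 3 `COc1cc(N)c(Cl)cc1C(=O)NC1CCN(CCCCCO)CC1` differs from compound 2 by 3-hydroxypropyl in place of hydrogen on a saturated chain carbon, two bonds along the chain from an amine nitrogen in a ring. Going by the values given here, no measured pair shows what such a chain extension does, so the step is judged from the structural change alone. Compound 3 is expected to give a somewhat lower number in this assay, a step of a 3.3-fold lower number from compound 2 to compound 3 (0.52 log units; beyond the scatter) that may just reach beyond the scatter. Compound 3 is estimated at 300 nM, with a range from 80 nM to 1200 nM.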

Compound 3, inhibition constant: 63.1 nM
For compound 3 the middle estimate is 4.8-fold (0.68 log units) above the measured one; the whole stated range lies above it.
By their numbers in this assay, from the lowest: compounds 3 and 1 (each within the scatter of the next); then compound 2.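

In this assay, 3-hydroxypropyl in place of hydrogen on a saturated chain carbon, two bonds along the chain from an amine nitrogen in a ring, gives a 16-fold lower number from compound 2 to compound 3 (1.20 log units; beyond the scatter) and so a large step beyond the scatter. This first measured pair at this position shows that a longer chain ending in a hydroxyl is accepted here, with the number falling rather than rising. Nothing at hand explains the size of this step.

A plain pentyl chain in place of 5-hydroxypentyl would separate the effect of added length from that of the hydroxyl. A chain ending in an amine or a carboxylic acid would show how much the end group matters.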